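The compounds below may be only part of what the source reports. "The series", "measured", "known", "first", "only" and "open" are said of these compounds alone.

Measured so far in a functional assay on MCF7 cells (Homo sapiens) for antiproliferative activity, read by MTT assay, with a stated time of 48 h (a higher number here means a weaker inhibitor, a lower number a stronger inhibitor), are these compounds
- compound 1 `CC(=O)OC/C1=C/C[C@](C)(CCC=C(C)C)/C=C/[C@@H](OC(=O)C=C(C)C)[C@](C)(O)/C=C/C1=O` with 4510 nM as its value
- compound 2 `CC(C)=CCC[C@]1(C)/C=C/[C@@H](OC(=O)C=C(C)C)[C@](C)(O)/C=C/C(=O)/C(Cn2cc(CO)nn2)=C\C1` with 2930 nM as its value

For the measured compounds named here, on these two numbers, compound 2 cannot be set apart from the only other measured compound. Placing 4-(hydroxymethyl)-1H-1,2,3-triazol-1-yl in place of acetoxy on a saturated chain carbon bound to a double-bonded ring carbon gave a 1.5-fold lower number from compound 1 to compound 2 (0.19 log units; within the scatter) and this stays within the scatter.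

Compound 3 `CC(C)=CCC[C@]1(C)/C=C/[C@@H](OC(=O)C=C(C)C)[C@](C)(O)/C=C/C(=O)/C(C(=O)N(C)C)=C\C1` has not yet been measured. Its difference from compound 2 is dimethylcarbamoyl in place of (4-(hydroxymethyl)-1H-1,2,3-triazol-1-yl)methyl on a double-bonded ring carbon and it places dimethylcarbamoyl in place of (4-(hydroxymethyl)-1H-1,2,3-triazol-1-yl)methyl on a double-bonded ring carbon. Going by the values given here, only the one measured step bears on this change, and it involved a different entering group, so it offers limited guidance. No step beyond the scatter is therefore expected in this assay and no direction can be favoured with confidence. The expected change is a 1.2-fold higher number from compound 2 to compound 3 (0.08 log units; within the scatter) and it starts from compound 2 at 2930 nM as its reference. For compound 3 the estimated value is 3500 nM with an expected range from 1300 nM to 10000 nM as its bounds.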

Compound 3, half-maximal inhibitory concentration: 3670 nM
For compound 3 the middle estimate is 1.0-fold (0.02 log units) below the measured one; the range from low to high includes it.
By their numbers in this assay, from the lowest: compounds 2, 3 and 1 (each within the scatter of the next).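

In this assay, for the compounds shown here, the double-bonded ring carbon now carries a third kind of group with no step that can be read as real: dimethylcarbamoyl gives a 1.3-fold higher number from compound 2 to compound 3 (0.10 log units; within the scatter) and a 1.2-fold lower number from compound 1 to compound 3 (0.09 log units; within the scatter). Going by these compounds alone, the earlier pair compared only two groups that both reach the ring carbon through a saturated chain carbon, whereas dimethylcarbamoyl has its carbonyl carbon directly on the ring carbon, and it has no ring and 0 hydrogen-bond donors, while the (4-(hydroxymethyl)-1H-1,2,3-triazol-1-yl)methyl group it replaces has a five-membered aromatic ring and 1 hydrogen-bond donor. Even these differences leave the three compounds within the scatter of one another, and nothing available explains this result.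

Going by these compounds, what remains open is whether any group at this place can produce a step beyond the scatter, for example a primary amine, a carboxylic acid or a longer alkyl chain on the same ring carbon. The three compounds also cannot show whether the other groups on the shared core, such as the ((2-methylprop-1-en-1-yl)carbonyl)oxy group, matter more for this number.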